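A few compounds are considered here, and "the series" means these few. Any claim that something is new, unique, unknown or untested is made for them only; others in the source may bear on it.

Measured compounds:

Compound 1, `C[C@@H](Cn1ccc(-c2ccc(C#N)c(Cl)c2)n1)Nc1ncccn1` — 1180 nM
Compound 2, `C[C@@H](Cn1ccc(-c2ccc(C#N)c(Cl)c2)n1)Nc1nccc(Cl)n1` — 1400 nM
Compound 3, `C[C@@H](Cn1ccc(-c2ccc(C#N)c(Cl)c2)n1)Nc1ncnc2nc[nH]c12` — 960 nM

Of the compounds shown here, three sharing one core have been tested in a functional assay on LNCaP cells (Homo sapiens) for antiproliferative activity, read by CCK-8 assay, with a stated time of 6 days; on this read-out higher numbers stand for weaker inhibition and lower numbers for stronger inhibition. Compound 1 `C[C@@H](Cn1ccc(-c2ccc(C#N)c(Cl)c2)n1)Nc1ncccn1` gives 1180 nM. Compound 2 `C[C@@H](Cn1ccc(-c2ccc(C#N)c(Cl)c2)n1)Nc1nccc(Cl)n1` gives 1400 nM; it differs from compound 1 by chloro in place of hydrogen on an aromatic carbon, and that change made a step of a 1.2-fold higher number from compound 1 to compound 2 (0.07 log units; within the scatter). Compound 3 `C[C@@H](Cn1ccc(-c2ccc(C#N)c(Cl)c2)n1)Nc1ncnc2nc[nH]c12` gives 960 nM. Its core differs from that of compound 1 by a group of 9 heavy atoms (5 carbon, 4 nitrogen; one five-membered aromatic ring with 2 hetero atoms, one six-membered aromatic ring with 2 hetero atoms) in place of a group of 6 heavy atoms (4 carbon, 2 nitrogen; one six-membered aromatic ring with 2 hetero atoms), on an amine nitrogen, a step of a 1.2-fold lower number from compound 1 to compound 3 (0.09 log units; within the scatter); against compound 2 the step is a 1.5-fold lower number from compound 2 to compound 3 (0.16 log units; within the scatter). All three numbers lie within the scatter of one another, so none of the three can be set apart from the others.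

Compound 4 `C[C@@H](Cn1ccc(-c2ccc(C#N)c(Cl)c2)n1)Nc1nc(Cl)nc2nc[nH]c12` has not yet been measured. It differs from compound 3 by chloro in place of hydrogen on an aromatic carbon. This is the same kind of change as that from compound 1 to compound 2, though the surroundings are not the same: in compound 2 the chloro sits next to the ring nitrogen, meta to a large group and opposite the ring nitrogen, whereas in compound 4 it sits between two ring nitrogen atoms, on a ring that is part of a fused system of two rings, meta and para to a fused ring and meta to a large group. In this assay, among the compounds with values here, the expected step from compound 3 to compound 4 is a 1.1-fold higher number from compound 3 to compound 4 (0.06 log units; within the scatter), set beside the measured 1.2-fold higher number from compound 1 to compound 2 (0.07 log units; within the scatter), because the earlier chloro brought a 1.2-fold higher number from compound 1 to compound 2 (0.07 log units; within the scatter) and nothing among the measured compounds points to a different outcome. Compound 4 is therefore estimated at 1100 nM, with a likely span from 500 nM to 2500 nM.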

Compound 4, half-maximal inhibitory concentration: 2660 nM
Compound 4: middle estimate off by 2.4-fold (0.38 log units), on the low side, and the stated range ends below it.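

In this assay, chloro in place of hydrogen on an aromatic carbon, here between two ring nitrogen atoms on a ring that is part of a fused system of two rings, gave a 2.8-fold higher number from compound 3 to compound 4 (0.44 log units; beyond the scatter), while on the core of compound 1 the same kind of change gave a 1.2-fold higher number from compound 1 to compound 2 (0.07 log units; within the scatter). This shows that the change can carry a cost beyond the scatter on one core while no cost can be read on the other, yet the two steps themselves cannot be told apart: the same change on two cores in this assay, a 1.2-fold higher number (0.07 log units; within the scatter) from compound 1 to compound 2 and a 2.8-fold higher number (0.44 log units; beyond the scatter) from compound 3 to compound 4, 2.3-fold (0.37 log units) apart, within the scatter of two such steps. Within the data shown here, the data therefore do not show that chloro behaves differently on the two cores, nor do they show that its effect carries over unchanged, as only two pairs of compounds bear on the question and the chloro stands in a different place on each.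

The compounds shown leave open whether a fluoro group, a methyl group or an amine on the same aromatic carbon would move the number in this assay as chloro does. They also leave open how the change from hydrogen to chloro would behave with any other group on the amine nitrogen.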